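The source may hold more compounds than are shown below. What is called first, only, known or untested is meant among the compounds shown, and "the series" means these compounds.

In an ADME assay on HepG2 cells (Homo sapiens) for cytotoxicity, read by MTT assay, with a stated time of 72 h (a lower number here means that less compound is tolerated, a higher number that more compound is tolerated), compound 1 (`CC(C)(C)Nc1nc2cc(-c3ccc(F)cc3)sc2c(=O)[nH]1`) gives 5100 nM, the lower of the two actual numbers in the series. Compound 2 (`COc1ccc(-c2cc3nc(NC(C)(C)C)[nH]c(=O)c3s2)cc1`) is the nearest, at 32300 nM. Compound 3 (`CC(C)Nc1nc2cc(-c3ccc(F)cc3)sc2c(=O)[nH]1`) gives > 25000 nM, which is a limit of the assay and not a number.

The step under consideration leads to compound 4 (`Cc1ccccc1-c1cc2nc(NC(C)(C)C)[nH]c(=O)c2s1`), with 2-methylphenyl in place of 4-fluorophenyl on an aromatic carbon, next to the ring sulfur: 2-methylphenyl in place of 4-fluorophenyl on an aromatic carbon. For the measured compounds named here, the closest precedent is a 6.3-fold higher number from compound 1 to compound 2 (0.80 log units; beyond the scatter), where methoxy replaces fluoro on the same aryl group. Going by the values given here, it is the only measured change to that group, and no measured compound carries 2-methylphenyl. The other measured step, an at least 4.9-fold higher number from compound 1 to compound 3 (0.69 log units; beyond the scatter), lies in the amine side chain, which compound 4 leaves unchanged, so it bears on the aryl swap only indirectly. It does show that compound 1 sits low against both neighbours.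

A modest rise in this assay is therefore expected, probably smaller than the one seen with methoxy, and a step within the scatter remains possible. The expected change is a 2.2-fold higher number from compound 1 to compound 4 (0.33 log units; beyond the scatter). For compound 4 the estimated value is 11000 nM, with an expected range from 4000 nM to 30000 nM.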

Compound 4, half-maximal cytotoxic concentration: 4000 nM
Compound 4: middle estimate off by 2.8-fold (0.44 log units), on the high side, and the stated range covers the measured number.
By their numbers in this assay, from the lowest: compounds 4 and 1 (each within the scatter of the next); then compound 2.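

In this assay, 2-methylphenyl in place of 4-fluorophenyl on this aromatic carbon, next to the ring sulfur, gives a 1.3-fold lower number from compound 1 to compound 4 (0.11 log units; within the scatter), so the read-out does not tell these two aryl groups apart. The aryl group is therefore not a place where every replacement of 4-fluorophenyl raises the number: methoxy in place of fluoro gave a 6.3-fold higher number from compound 1 to compound 2 (0.80 log units; beyond the scatter), and the 2-methylphenyl swap does not repeat that step. Nothing measured here accounts for either outcome or ties one to a property of the groups.

On these data alone, whether 4-methylphenyl, 2-fluorophenyl or an aryl group carrying an amine or a carboxylic acid would stay level with compound 1 or follow compound 2 remains open, and these groups would show whether the identity of the substituent or its place on the aryl ring matters more. As far as these compounds go, the side-chain step, an at least 4.9-fold higher number from compound 1 to compound 3 (0.69 log units; beyond the scatter), rests on a limit and is known only with 4-fluorophenyl, so whether it carries over to 2-methylphenyl is also open.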